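Pyridinyl series: the step to compound 4

A few compounds are considered here, and "the series" means these few. Any claim that something is new, unique, unknown or untested is made for them only; others in the source may bear on it.

Values in a functional assay on MCF7 cells (Homo sapiens) for antiproliferative activity, read by MTT assay, with a stated time of 48 h (on this read-out lower numbers stand for stronger inhibition and higher numbers for weaker inhibition), for the series:
compound 1 `CC(=O)N1N=C(c2ccc3ccccc3c2)OC1c1ccc(F)cc1` gives 3.02 ug/mL
compound 2 `CC(=O)N1N=C(c2ccc3ccccc3c2)OC1c1ccccn1` gives 6.02 ug/mL
compound 3 `CC(=O)N1N=C(c2ccc3ccccc3c2)OC1c1cccnc1` gives 2.61 ug/mL
compound 4 `CC(=O)N1N=C(c2ccc3ccccc3c2)OC1c1ccncc1` is not yet measured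

Compound 3 stands at 2.61 ug/mL with a 1.2-fold lower number from compound 1 to compound 3 (0.06 log units; within the scatter) as its nearest comparison. The next change is pyridin-4-yl in place of pyridin-3-yl on a saturated ring carbon with the rest of the structure unchanged. Within the data shown here, the only measured exchange between pyridinyl isomers gave a 2.3-fold lower number from compound 2 to compound 3 (0.36 log units; beyond the scatter) and the exchange of 4-fluorophenyl for pyridin-2-yl gave a 2.0-fold higher number from compound 1 to compound 2 (0.30 log units; within the scatter) so these steps favour no clear direction. The estimate means a 1.2-fold higher number from compound 3 to compound 4 (0.09 log units; within the scatter) and no step beyond the scatter is expected in this assay here. For compound 4 the expected value is 3.2 ug/mL with an estimated range from 1.6 ug/mL to 6.5 ug/mL at this stage.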

Compound 4, half-maximal inhibitory concentration: 2.56 ug/mL
Estimate against measurement, compound 4: 1.3-fold (0.10 log units) above; the measured number falls inside the stated range.
By their numbers in this assay, from the lowest: compounds 4, 3, 1 and 2 (each within the scatter of the next, the first and the last beyond it).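

In this assay, pyridin-4-yl and pyridin-3-yl at this saturated ring carbon cannot be told apart, with a 1.0-fold lower number from compound 3 to compound 4 (0.01 log units; within the scatter). Pyridin-4-yl also stays level with 4-fluorophenyl, with a 1.2-fold lower number from compound 1 to compound 4 (0.07 log units; within the scatter). Among the three pyridinyl isomers, only pyridin-2-yl now stands apart, with a 2.4-fold lower number from compound 2 to compound 4 (0.37 log units; beyond the scatter), although compound 1 and compound 2 lie within the scatter of each other.

No supporting measurement accounts for this isomer pattern. Open, from the compounds shown here alone, is how a morpholine or a benzoic acid at this carbon would compare, and how replacing the acetyl group with a longer acyl chain would read.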